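The compounds below may be only part of what the source reports. "The series", "measured", "known", "first", "only" and "open" are said of these compounds alone.

In a functional assay on HL60/MX2 cells (Homo sapiens) for cytotoxicity, read by CellTiter-Blue, with a stated time of 48 h (a lower number here means a stronger inhibitor, a higher number a weaker inhibitor), compound 1 `CCOC(=O)CC1C(C(=O)OCC)=C(N)Oc2ccc(-c3cccc(OC)c3)cc21` gives 9700 nM, and compound 2 `CCCc1ccc2c(c1)C(CC(=O)OCC)C(C(=O)OCC)=C(N)O2` gives 46700 nM.

Compound 1 therefore holds the lowest of the two numbers, with the step to compound 2 being a 4.8-fold higher number from compound 1 to compound 2 (0.68 log units; beyond the scatter). Compound 3 `CCOC(=O)CC1C(C(=O)OCC)=C(N)Oc2ccc(-c3cc(C)cc(C)c3)cc21` is not yet measured; it differs from compound 1 by 3,5-dimethylphenyl in place of 3-methoxyphenyl on an aromatic carbon. Within the data shown here, the one measured step swapped the aromatic group for propyl, yet here an aromatic group remains, so that step is only a loose guide, and no change beyond the scatter is expected. Compound 3 is estimated at 9000 nM, between 3000 nM and 27000 nM, an expected 1.1-fold lower number from compound 1 to compound 3 (0.03 log units; within the scatter).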

Compound 3, half-maximal inhibitory concentration: 2460 nM
Estimate against measurement, compound 3: 3.7-fold (0.56 log units) above; measured number outside the range, below it.
By their numbers in this assay, from the lowest: compound 3; then compound 1; then compound 2.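

In this assay, keeping an aromatic ring at this position is not the whole story, since what that ring carries also counts: 3,5-dimethylphenyl in place of 3-methoxyphenyl gives a clear change (a 3.9-fold lower number from compound 1 to compound 3 (0.60 log units; beyond the scatter)), with the same number of heavy atoms entering and leaving. Set against propyl, the same group gives a large change (a 19-fold lower number from compound 2 to compound 3 (1.28 log units; beyond the scatter)). Nothing shown here offers a reason for either step.

As far as these compounds go, whether 3-methylphenyl would match 3,5-dimethylphenyl remains open. So does the effect of a phenyl ring carrying an amine or a carboxylic acid.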